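The source may report more compounds than this note shows. Statements on the series, on what has been measured and on what is new or still open speak of the compounds shown alone.

Compound 2 `COc1ccc(NC(=O)COc2cc(C)nc3ccc(OC)cc23)cc1` carries the shared core with a 4-methoxyphenyl on an amide-type nitrogen. In a physicochemical assay for solubility, in phosphate buffer, measured as kinetic solubility, with a stated time of 1 h, at pH 7.4 (on this read-out lower numbers stand for lower solubility and higher numbers for higher solubility), compound 2 gives 108000 nM, the highest of the two numbers in hand. For the measured compounds named here, its only measured neighbour is compound 1 `COc1ccc2nc(C)cc(OCC(=O)Nc3cc(C)ccc3C)c2c1`, which in this assay gives 45500 nM; the difference, a 2.4-fold higher number from compound 1 to compound 2 (0.38 log units; beyond the scatter), came with 4-methoxyphenyl in place of 2,5-dimethylphenyl on an amide-type nitrogen. Compound 3 `COc1ccc2nc(C)cc(OCC(=O)Nc3cc(F)cc(F)c3)c2c1` has not been measured. It differs from compound 2 in one place: 3,5-difluorophenyl in place of 4-methoxyphenyl on an amide-type nitrogen. Going by the values given here, the group that enters carries no hydrogen-bond acceptor, whereas the 4-methoxyphenyl that leaves carries one, and in the single measured step the group without an acceptor, 2,5-dimethylphenyl, went with the lower number. Among the compounds with values here, that step is the only guide here, and it was modest. A modest fall in this assay is therefore expected for compound 3, of about a 2.2-fold lower number from compound 2 to compound 3 (0.33 log units; beyond the scatter), which would place it near the number seen for compound 1. The estimate for compound 3 in this assay is 50000 nM, with a range from 20000 nM to 120000 nM.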

Compound 3, solubility: 13000 nM
For compound 3 the middle estimate is 3.8-fold (0.59 log units) above the measured one, outside the stated range (below it).
By their numbers in this assay, from the lowest: compound 3; then compound 1; then compound 2.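

In this assay, the group on an amide-type nitrogen proved able to move the read-out further than the first pair had shown: replacing 4-methoxyphenyl with 3,5-difluorophenyl gave (an 8.3-fold lower number from compound 2 to compound 3 (0.92 log units; beyond the scatter)), a wider gap than the earlier (a 2.4-fold higher number from compound 1 to compound 2 (0.38 log units; beyond the scatter)). For the compounds shown here, the new compound also separates two groups that carry no hydrogen-bond acceptor, with (a 3.5-fold lower number from compound 1 to compound 3 (0.54 log units; beyond the scatter)), so the lack of an acceptor does not by itself fix the number, although the only group here that has one, in compound 2, does stand highest of the three. Nothing on record explains these differences, and the size of the fall cannot be assigned to the fluorines, to the loss of the methoxy group or to any other feature of the exchange.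

The compounds shown leave open how a phenyl ring bearing a single fluorine, a nitrile, an amine or a carboxylic acid would read at this position. They also leave open whether the same order among these three groups would hold on a core with a longer chain in place of the one shared here.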